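The source may report more compounds than this note shows. Statements on the series, on what has been measured and on what is new or still open speak of the compounds shown alone.

In a functional assay on PC-3 cells (Homo sapiens) for inhibition, read by sulforhodamine B assay, with a stated time of 48 h, tested at 50 uM (a higher number here means more inhibition of growth at the concentration tested, a lower number less inhibition of growth), compound 3 `COc1cc(/C=C/C(=O)/C=C/c2ccccc2)ccc1OCc1cn(CCOc2cc(=O)oc3ccccc23)nn1` gives 10%. Compound 1 `COc1cc(/C=C/C(=O)/C=C/c2cccs2)ccc1OCc1cn(CCOc2cc(=O)oc3ccccc23)nn1` gives 12%, within the scatter of that number, while compound 2 `COc1cc(/C=C/C(=O)/C=C/c2cc(OC)c(OC)c(OC)c2)ccc1OCc1cn(CCOc2cc(=O)oc3ccccc23)nn1` gives 22%. Compound 4 `COc1cc(/C=C/C(=O)/C=C/c2ccco2)ccc1OCc1cn(CCOc2cc(=O)oc3ccccc23)nn1` is compound 3 with one change, furan-2-yl in place of phenyl on a double-bonded chain carbon bound to a double-bonded chain carbon. The closest guide is the exchange of thiophen-2-yl for phenyl at that place, which gave a number 2 percentage points lower from compound 1 to compound 3 (within the scatter). The exchange of 3,4,5-trimethoxyphenyl for phenyl gave a larger change, a number 12 percentage points lower from compound 2 to compound 3 (beyond the scatter), but compound 4 lacks that group. The estimated step in this assay is therefore a number 1 percentage points higher from compound 3 to compound 4 (within the scatter), so nothing beyond the scatter is expected. For compound 4 the expected value is 11%, with an estimated range from 4% to 20%.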

Compound 4, percent growth inhibition at one concentration: 14%
Beside the measured number, compound 4's estimate is 3 percentage points below it; the measured number falls inside the stated range.
By their numbers in this assay, from the lowest: compounds 3, 1, 4 and 2 (each within the scatter of the next, the first and the last beyond it).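

In this assay furan-2-yl on a double-bonded chain carbon bound to a double-bonded chain carbon cannot be told apart from phenyl (a number 4 percentage points higher from compound 3 to compound 4 (within the scatter)) or from thiophen-2-yl (a number 2 percentage points higher from compound 1 to compound 4 (within the scatter)). For the compounds shown here, it also cannot be told apart from 3,4,5-trimethoxyphenyl (a number 8 percentage points lower from compound 2 to compound 4 (within the scatter)), so compound 4 falls clearly with neither compound 2 nor compound 3, the only pair separated beyond the scatter. No measurement shown here gives a reason for these numbers.

As far as these compounds go, only aromatic rings appear at this place, so what an amine or a carboxylic acid there would give remains open. Also open, from the compounds shown here alone, is whether a longer chain in its place would move the number beyond the scatter.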